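The source may hold more compounds than are shown below. What is called first, only, known or untested is meant among the compounds shown, and "the series" means these compounds.

In a functional assay on cells (Neutrophil, Homo sapiens) for inhibition, with a stated time of 10 min (on this read-out higher numbers stand for weaker inhibition and lower numbers for stronger inhibition), compound 1 (`CCCC(O)Cn1ncc(C(=O)OCC)c1NC(=O)NC(C)C`) gives 1 nM. That lies within the scatter of compound 3 (`CCOC(=O)c1cnn(CC(O)CC)c1NC(=O)Nc1ccc(F)cc1`), which gives 1.9 nM, while compound 2 (`CCOC(=O)c1cnn(CC(O)CC)c1NC(=O)Nc1ccccc1F`) gives a far lower 0.0016 nM. Among the compounds with values here, the only measured step, a 1200-fold higher number from compound 2 to compound 3 (3.07 log units; beyond the scatter), puts 4-fluorophenyl in place of 2-fluorophenyl on an amide-type nitrogen.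

Compound 4 (`CCOC(=O)c1cnn(C)c1NC(=O)NC(C)C`) is changed elsewhere: hydrogen in place of 1-hydroxybutyl on a saturated chain carbon bound to an aromatic nitrogen, with hydrogen in place of 1-hydroxybutyl on a saturated chain carbon bound to an aromatic nitrogen. The measured step therefore bears on this change only indirectly, showing that one small edit can move the number a long way. Within the data shown here, no measured compound tests this place, so the direction remains uncertain. A moderately higher number in this assay, meaning weaker inhibition, is a cautious expectation, and a result within the scatter would be no surprise. The expected change is a 5.0-fold higher number from compound 1 to compound 4 (0.70 log units; beyond the scatter). Compound 4 is estimated at 5 nM, with an expected range of 0.2 nM to 100 nM.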

Compound 4, half-maximal inhibitory concentration: 0.0018 nM
For compound 4 the middle estimate is 2800-fold (3.44 log units) above the measured one; the measured number lies below the stated range.
By their numbers in this assay, from the lowest: compounds 2 and 4 (each within the scatter of the next); then compounds 1 and 3 (each within the scatter of the next).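

In this assay, the place on a saturated chain carbon bound to an aromatic nitrogen proves highly sensitive: hydrogen in place of 1-hydroxybutyl, which can also be read as 2-hydroxypentyl to methyl, gives a 560-fold lower number from compound 1 to compound 4 (2.74 log units; beyond the scatter) and so much stronger inhibition. In this pair, the longer hydroxyl-bearing chain is therefore not needed for strong inhibition, a point the earlier step on the fluorophenyl group could not address. Nothing available explains why the number falls so far.

A plain pentyl chain or a 2-aminopentyl group at this place would help show whether the hydroxyl or the chain length goes with the change. As far as these compounds go, whether the same swap would act alike alongside the 2-fluorophenyl group of compound 2 also stays open.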